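The source may hold more compounds than are shown below. What is called first, only, known or untested is meant among the compounds shown, and "the series" means these compounds.

Of the compounds shown here, three sharing one core have been measured in a functional assay on AGS cells (Homo sapiens) for antiproliferative activity, read by CCK-8 assay, with a stated time of 72 h; a higher number here means a weaker inhibitor, a lower number a stronger inhibitor. Compound 1 `O=C(Nc1ccc(-c2cnc3cc(N4CCN(C5CC5)CC4)ccn23)cc1)c1ccc([N+](=O)[O-])o1` gives 1920 nM, compound 2 `O=C(Nc1ccc(-c2cnc3cc(C4=CCN(C5COC5)CC4)ccn23)cc1)c1ccc([N+](=O)[O-])o1` gives 790 nM, and compound 3 `O=C(Nc1ccc(-c2cnc3cc(Cl)ccn23)cc1)c1ccc([N+](=O)[O-])o1` gives 1700 nM. On these numbers compound 3 stands second highest of the three: its number and that of compound 1 lie within the scatter of each other, while the step of a 2.2-fold higher number from compound 2 to compound 3 (0.33 log units; beyond the scatter) is a modest one.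

Compound 4 `O=C(Nc1ccc(-c2cnc3ccccn23)cc1)c1ccc([N+](=O)[O-])o1` differs from compound 3 by hydrogen in place of chloro on an aromatic carbon. Among the measured compounds shown here, two measured steps bear on this place on the core. The step of a 1.1-fold lower number from compound 1 to compound 3 (0.05 log units; within the scatter) shows that swapping a sizeable group for chloro changed the number within the scatter only, and the step of a 2.2-fold higher number from compound 2 to compound 3 (0.33 log units; beyond the scatter) shows a modest change for another sizeable group. Because the step of a 1.1-fold lower number from compound 1 to compound 3 (0.05 log units; within the scatter) lies within the scatter and the step of a 2.2-fold higher number from compound 2 to compound 3 (0.33 log units; beyond the scatter) is only modest, removing the chlorine atom altogether is expected to produce no step beyond the scatter, so compound 4 is estimated at 1800 nM with a range from 700 nM to 4500 nM, an expected step of a 1.1-fold higher number from compound 3 to compound 4 (0.02 log units; within the scatter).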

Compound 4, half-maximal inhibitory concentration: 360 nM
Estimate against measurement, compound 4: 5.0-fold (0.70 log units) above; the whole stated range lies above it.
By their numbers in this assay, from the lowest: compound 4; then compound 2; then compounds 3 and 1 (each within the scatter of the next).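

Removing the chlorine atom from this carbon, opposite the ring nitrogen, does more than any swap among the earlier groups, with a 4.7-fold lower number from compound 3 to compound 4 (0.67 log units; beyond the scatter) in this assay. The two larger groups also compare poorly with hydrogen, with a 2.2-fold lower number from compound 2 to compound 4 (0.34 log units; beyond the scatter) and a 5.3-fold lower number from compound 1 to compound 4 (0.73 log units; beyond the scatter), so all three groups shown here give higher numbers than the unsubstituted position, something the earlier compounds could not show while each carried a group at this place. Nothing measured here explains this result.

On these data alone, it remains open whether hydrogen is unusual at this carbon or whether fluoro, methyl or methoxy would give a similarly low number. Also open, as far as these compounds go, is how an amine on a short chain, such as aminomethyl, would compare with the larger ring-bearing groups.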